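A few compounds are considered here, and "the series" means these few. Any claim that something is new, unique, unknown or untested is made for them only; others in the source may bear on it.

Three measured compounds and one still unmeasured were examined in a functional assay on SW480 cells (Homo sapiens) for cytotoxicity, read by MTT assay, with a stated time of 24 h; a lower number here means a stronger inhibitor, a higher number a weaker inhibitor. Compound 1 `C=CC1=C(C(=O)NCCC)C(c2ccc(F)cc2)OC1` is the starting point. In this assay compound 1 reaches only the limit > 100000 nM, which is a limit of the assay and not a number. Compound 2 `C=CC1=C(C(=O)NCC(C)C)C(c2ccc(F)cc2)OC1` differs from compound 1 by methyl in place of hydrogen on a saturated chain carbon bound to two saturated chain carbons. In this assay compound 2 likewise sits at the limit > 100000 nM. Compound 3 `C=CC1=C(C(=O)NCCC)C(c2ccc(OC)cc2)OC1` differs from compound 1 by methoxy in place of fluoro on an aromatic carbon. In this assay compound 3 also gives only the limit > 100000 nM. The step that the two limits leave unreadable from compound 1 to compound 2 and the step that the two limits leave unreadable from compound 1 to compound 3 cannot be sized, because of the limit of > 100000 nM in this assay, at which 3 of the 3 values shown sit. Compound 4 `C=CC1=C(C(=O)NCC(C)C)C(c2ccc(OC)cc2)OC1` differs from compound 3 by methyl in place of hydrogen on a saturated chain carbon bound to two saturated chain carbons, the same change, at the same place, that leads from compound 1 to compound 2. Since that change left compound 1 and compound 2 both at the limit, compound 4 is expected to stay at the limit too, an expected step of a number no higher from compound 3 to compound 4 (the limit leaves the size open). Compound 4 is therefore estimated at 100000 nM, most likely reported as a limit again.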

Compound 4, half-maximal inhibitory concentration: > 100000 nM
Compound 4: no number, only a limit; the forecaster's own chance of this, stated with the estimate: 85%; the middle value lies on the limit itself.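

In this assay compound 4 gives only a limit, so neither the step from compound 3 to it nor the step from compound 2 to it can be read, because these compounds share one limit of the assay: the limit of > 100000 nM in this assay, at which 4 of the 4 values shown sit. The compounds shown leave open how far the four compounds actually differ, and whether any change at these two places would give a readable value in this assay.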